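The compounds below may be only part of what the source reports. "The series", "measured", "known", "first", "only" and "open" are said of these compounds alone.

Of the compounds shown here, three built on the same core have been measured in an assay on CHO-K1 cells for antagonist activity at transient receptor potential cation channel subfamily V member 1 (Homo sapiens), read by FLIPR and calcium flux, with a stated time of 6 min; a higher number here means a weaker inhibitor, a lower number a stronger inhibitor. Compound 1 `Cn1ncc2c(NC(=O)NCc3cc(C(F)(F)F)nn3-c3ccc(Cl)cc3)cccc21` gives 2.7 nM there. Compound 2 `Cn1ncc2c(NC(=O)NCc3cc(C(F)(F)F)nn3-c3ccc(C(F)(F)F)cc3)cccc21` gives 3.9 nM, and compound 3 `Cn1ncc2c(NC(=O)NCc3cc(C(F)(F)F)nn3-c3ccc(F)c(Cl)c3)cccc21` gives 1.9 nM. The three differ only in the aryl group on the ring nitrogen of the five-membered ring. The step of a 1.4-fold higher number from compound 1 to compound 2 (0.16 log units; within the scatter) and the step of a 1.4-fold lower number from compound 1 to compound 3 (0.15 log units; within the scatter) both stay inside the scatter, while the step of a 2.1-fold lower number from compound 2 to compound 3 (0.31 log units; beyond the scatter) is modest but beyond it. Compound 3 thus holds the lowest of the three numbers; compound 1 sits within the scatter of it, and compound 2 lies beyond.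

Compound 4 `Cn1ncc2c(NC(=O)NCc3cc(C(C)(C)C)nn3-c3ccc(F)c(Cl)c3)cccc21` keeps the 3-chloro-4-fluorophenyl group of compound 3 and changes a different position: tert-butyl in place of trifluoromethyl on an aromatic carbon. Going by the values given here, none of the measured steps touches this position; all three concern the aryl group on the ring nitrogen, so no measured step bears directly on the change. Nothing in the set therefore argues for a step beyond the scatter in either direction, and the expectation is a step of a 1.6-fold higher number from compound 3 to compound 4 (0.20 log units; within the scatter) in this assay, essentially none beyond the scatter. Compound 4 is estimated at 3 nM, with a range from 1 nM to 10 nM.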

Compound 4, inhibition constant: 0.6 nM
For compound 4 the middle estimate is 5.0-fold (0.70 log units) above the measured one; measured number below the stated range.
By their numbers in this assay, from the lowest: compound 4; then compounds 3, 1 and 2 (each within the scatter of the next, the first and the last beyond it).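

Until this point every step concerned the aryl group on the ring nitrogen; a 3.2-fold lower number from compound 3 to compound 4 (0.50 log units; beyond the scatter) in this assay now shows that the number also responds to the group on the aromatic carbon of the five-membered ring, by a modest step beyond the scatter. The change is a narrow one in what can be counted: trifluoromethyl and tert-butyl both have 4 heavy atoms, with no ring, no hydrogen-bond donor or acceptor and no net charge, and they differ in that tert-butyl has 4 carbon where trifluoromethyl has 1 carbon and 3 fluorine. Nothing in the data shown gives a reason for this step.

In the compounds shown, tert-butyl appears only together with the 3-chloro-4-fluorophenyl group, so it remains open whether a step of this direction and size would also appear with 4-chlorophenyl or 4-(trifluoromethyl)phenyl on the ring nitrogen. Also open, from the compounds shown here alone, is how this assay would read with a methyl group, a cyclopropyl ring or an amine on this aromatic carbon.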